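Working notes: step from compound 2 to compound 3

The source may hold more compounds than are shown below. What is called first, only, known or untested is meant among the compounds shown, and "the series" means these compounds.

Measured values in a functional assay on the whole organism (strain Swiss) for inhibition, with Mus musculus as the target, with stated times of 40 min and 6 h, at a dose of 100 mg/kg by the oral route; a higher number here means more inhibition at the dose given (going by the name of the read-out), a lower number less inhibition:
compound 1 `O=C(N/N=C/c1ccc(-c2ccccc2)cc1)c1cnccn1` gives 14.4%
compound 2 `O=C(N/N=C/c1ccccc1)c1cnccn1` gives 21.7%

For the measured compounds named here, compound 2 stands highest of the two numbers; its only neighbour is compound 1, and the single step, a number 7.3 percentage points higher from compound 1 to compound 2 (within the scatter), lies within the scatter, so no order between the two compounds can be claimed. Compound 3 `CC(C)c1ccc(/C=N/NC(=O)c2cnccn2)cc1` differs from compound 2 by isopropyl in place of hydrogen on an aromatic carbon. Going by the values given here, the one measured step that bears on this is a number 7.3 percentage points higher from compound 1 to compound 2 (within the scatter), in which hydrogen replaced phenyl on an aromatic carbon without a change beyond the scatter. Among the compounds with values here, compound 3 goes the other way, a group entering at an aromatic carbon, and the one step known gives no ground for a move beyond the scatter in this assay in either direction. The expected value of compound 3 is 18%, in the range 5% to 32%. The step this estimate means, a number 3.7 percentage points lower from compound 2 to compound 3 (within the scatter), is expected to stay within the scatter.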

Compound 3, a percentage reported as inhibition, in the whole organism at one dose (the size of the read-out at that dose, not a potency): 19.4%
Estimate against measurement, compound 3: 1.4 percentage points below, within the range that was stated.
By their numbers in this assay, from the lowest: compounds 1, 3 and 2 (each within the scatter of the next).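

In this assay, the aromatic carbon para to a large group has now carried hydrogen, phenyl and isopropyl, and no exchange among them leaves the scatter: the entry of isopropyl gives (a number 2.3 percentage points lower from compound 2 to compound 3 (within the scatter)) and the exchange of phenyl for isopropyl gives (a number 5 percentage points higher from compound 1 to compound 3 (within the scatter)). The earlier pair showed this for phenyl alone; the same now holds for a group with no ring, so at this dose neither of the two groups separates from hydrogen or from the other. Nothing measured here bears on why these numbers lie so close.

On these data alone, whether an amine or a carboxylic acid on this same carbon would give a step beyond the scatter remains open. So does whether any change elsewhere on the shared core would do so.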